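Lengthening a Chain by One Carbon: an Expected Shift

A few compounds are considered here, and "the series" means these few. Any claim that something is new, unique, unknown or untested is made for them only; others in the source may bear on it.

Measured so far, in a physicochemical assay for lipophilicity; on this read-out lower numbers stand for lower lipophilicity and higher numbers for higher lipophilicity:
compound 1, `CCCCCCCCCNC(=O)Oc1ccc(Cl)cc1C(=O)Nc1cccc(Cl)c1`, gives 6.78
compound 2, `CCCCCCCCCCNC(=O)Oc1ccc(Cl)cc1C(=O)Nc1cccc(Cl)c1`, gives 7.19
compound 3, `CCCCCCCCNC(=O)Oc1ccc(Cl)cc1C(=O)Nc1ccc(Cl)c(Cl)c1`, gives 6.92

Compound 1 and compound 2 share one core and differ in a single place: methyl in place of hydrogen on a saturated chain carbon, nine bonds along the chain from an amide-type nitrogen. That change produced a number 0.41 log units higher from compound 1 to compound 2 (beyond the scatter). Compound 3 is built on a different core; how the core of compound 3 differs from the core of compound 1 is not broken down here. In this assay the value of compound 3 lies within the usual scatter of both compound 1 and compound 2, so nothing can be said about an order among the three.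

Compound 4, `CCCCCCCCCNC(=O)Oc1ccc(Cl)cc1C(=O)Nc1ccc(Cl)c(Cl)c1`, has not yet been measured. It differs from compound 3 in one place: methyl in place of hydrogen on a saturated chain carbon, eight bonds along the chain from an amide-type nitrogen. For the measured compounds named here, this is the same kind of change as the one between compound 1 and compound 2, though the place differs in wording: eight bonds along the chain from an amide-type nitrogen here, nine bonds there. For compound 4 the expected step is a number 0.41 log units higher from compound 3 to compound 4 (beyond the scatter). Going by the values given here, this rests on the single earlier instance, which gave a number 0.41 log units higher from compound 1 to compound 2 (beyond the scatter); with only one such instance the range is kept fairly wide. In this assay compound 4 is therefore estimated at 7.33, with a likely range from 7 to 7.65.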

Compound 4, partition coefficient: 7.34
Beside the measured number, compound 4's estimate is 0.01 log units below it; measured number inside the range.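

In this assay the same added methyl gave a number 0.42 log units higher from compound 3 to compound 4 (beyond the scatter) on one core, and on the other core it gave a number 0.41 log units higher from compound 1 to compound 2 (beyond the scatter), so the two steps are nearly the same size and the change carried over between these two cores. For the compounds shown here, the two cores are themselves only one small change apart, as the chloro in place of hydrogen on an aromatic carbon gives a number 0.56 log units higher from compound 1 to compound 4 (beyond the scatter), so this is one pairing of closely related cores and shows nothing yet about cores that differ more widely, or about whether the step stays this size at other chain lengths. Nothing measured here explains why the step repeats, so the agreement stands as an observation without a stated cause.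

The compounds shown all carry plain saturated chains, which leaves open whether the same step would appear on a chain longer than that of compound 2, or on a chain that also carries an amine or a carboxylic acid. They also leave open what happens to the step on a core where the chloro is exchanged for another group such as trifluoromethyl or nitrile, since only chloro and hydrogen appear at that place.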